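An aryl ether swap on a pyridine nicotinic ligand

The source may hold more compounds than are shown below. What is called first, only, known or untested is meant among the compounds shown, and "the series" means these compounds.

Compound 2 `COc1ccccc1Oc1cncc(C2=CC3CNCC(C2)C3)c1` shows the lowest number of the three in an in vitro assay on SH-EP1 cells for displacement of a labelled ligand from Neuronal acetylcholine receptor; alpha4/beta2 (Homo sapiens) (a lower number here means a stronger inhibitor, a higher number a weaker inhibitor), at 1 nM. Compound 3 `C1=C(c2cnccn2)CC2CNCC1C2` lies within the scatter of it, giving 1.1 nM in this assay, so the two cannot be ordered. Compound 1 `CN1C[C@H]2C=C(c3cccnc3)C[C@H](C2)C1` gives 2.1 nM in this assay, and its gap to compound 2 exceeds the scatter. Compound 4 `Clc1cccc(Oc2cncc(C3=CC4CNCC(C3)C4)c2)c1` differs from compound 2 by 3-chlorophenyl in place of 2-methoxyphenyl on an oxygen on an aromatic ring. Among the compounds with values here, no measured pair shows this change, so its effect has not been seen directly. The step of a 1.5-fold higher number from compound 2 to compound 4 (0.18 log units; within the scatter) is expected to stay within the scatter, in neither direction. For compound 4 the estimate in this assay is 1.5 nM, expected to fall between 0.4 nM and 6 nM.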

Compound 4, inhibition constant: 1 nM
Estimate against measurement, compound 4: 1.5-fold (0.18 log units) above; the range from low to high includes it.
By their numbers in this assay, from the lowest: compounds 2, 4, 3 and 1 (each within the scatter of the next, the first and the last beyond it).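

In this assay, within the data shown here, 3-chlorophenyl in place of 2-methoxyphenyl on an oxygen on an aromatic ring gives no change at the digits printed from compound 2 to compound 4 (within the scatter), a direct reading of a change at this position that the earlier compounds did not offer. The hydrogen-bond acceptor counted in 2-methoxyphenyl is absent from 3-chlorophenyl, yet this pair stays within the scatter. Nothing given here explains why the two groups read alike. From the compounds shown here alone, whether this holds with an amine or a carboxylic acid on that phenyl ring, or with a short alkyl chain replacing the ring, stays open.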